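Series notes: methoxy in place of chloro, compound 3

A few compounds are considered here, and "the series" means these few. Any claim that something is new, unique, unknown or untested is made for them only; others in the source may bear on it.

compound 1 `N#C/C(=C\c1ccccc1)C(=O)NCc1ccc(Cl)c(Cl)c1` — 43000 nM in a functional assay on SJ-G2 cells (Homo sapiens) for inhibition, read by MTT assay, with a stated time of 72 h; a higher number here means a weaker inhibitor of growth, a lower number a stronger inhibitor of growth
compound 2 `N#C/C(=C\c1ccc(Cl)cc1)C(=O)NCc1ccc(Cl)c(Cl)c1` — 30000 nM in this assay

Compound 2 stands at the lower end of the two numbers shown, with compound 1 within the scatter of it, so the two are not separable. Going by the values given here, the only measured step, a 1.4-fold lower number from compound 1 to compound 2 (0.16 log units; within the scatter), adds a chloro on an aromatic carbon and stays within the scatter. Compound 3 `COc1ccc(/C=C(\C#N)C(=O)NCc2ccc(Cl)c(Cl)c2)cc1` differs from compound 2 by methoxy in place of chloro on an aromatic carbon. Among the compounds with values here, no measured step covers a methoxy for chloro exchange, and the single step on that ring is within the scatter, so no step beyond the scatter is expected in this assay. Compound 3 is estimated at 35000 nM, range 15000 nM to 85000 nM, the expected step being a 1.2-fold higher number from compound 2 to compound 3 (0.07 log units; within the scatter).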

Compound 3, concentration for 50% growth inhibition: > 100000 nM
Compound 3 gave a limit, no number; the forecaster's own chance of this, stated with the estimate: 10%; middle value at least 2.8-fold (0.45 log units) away from the limit.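

Para to a large group on the ring, the earlier chloro for hydrogen exchange left compound 1 and compound 2 inseparable, so this position had shown no step beyond the scatter. Methoxy is the first group here to separate from both, with an at least 3.3-fold higher number from compound 2 to compound 3 (0.52 log units; beyond the scatter) against chloro and an at least 2.3-fold higher number from compound 1 to compound 3 (0.36 log units; beyond the scatter) against hydrogen. Compound 3 gives a limit in this assay, not a number: the limit of > 100000 nM in this assay, at which 1 of the 3 values shown sits.

From the compounds shown here alone, how far compound 3 lies past that limit stays open. Also open, going by these compounds, is whether hydroxy, an amine or ethoxy at this carbon would read like chloro or like methoxy.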